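The source may hold more compounds than are shown below. What is called first, only, known or untested is meant among the compounds shown, and "the series" means these compounds.

Measured compounds:
- Compound 1, `CCN(CCCCn1sc2cc(OC)c(OC)cc2c1=O)Cc1ccccc1`: 20100 nM
- Compound 2, `COc1cc2sn(CCCCCCN(C)Cc3ccccc3)c(=O)c2cc1OC`: 13200 nM

Both compounds were tested in an assay on isolated protein for inhibition of Amine oxidase [flavin-containing] B (Homo sapiens), read by fluorescence, with a stated time of 30 min; a higher number here means a weaker inhibitor, a lower number a stronger inhibitor. Compound 1 gives 20100 nM there, and compound 2 gives 13200 nM. These two numbers lie within the usual scatter of each other, so neither compound can be called the stronger inhibitor; compound 2 simply stands level with compound 1 on the numbers shown. Compound 1 and compound 2 differ in more than one place. For the measured compounds named here, no single step between them can be read.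

Compound 3, `CCN(CCCCCCn1sc2cc(OC)c(OC)cc2c1=O)Cc1ccccc1`, has not yet been measured. It differs from compound 2 by methyl in place of hydrogen on a saturated chain carbon bound to an amine nitrogen. Going by the values given here, the data hold no step that isolates this kind of change, so there is no direct guide to its effect. The expectation is a step from compound 2 to compound 3 of a 1.0-fold lower number from compound 2 to compound 3 (0.01 log units; within the scatter), meaning nothing beyond the scatter in either direction. Compound 3 is therefore estimated at 13000 nM, within a range from 5000 nM to 35000 nM.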

Compound 3, half-maximal inhibitory concentration: 20100 nM
For compound 3 the middle estimate is 1.5-fold (0.19 log units) below the measured one, and the stated range covers the measured number.
By their numbers in this assay, from the lowest: compounds 2, 1 and 3 (each within the scatter of the next).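

Going from benzyl(methyl)amino to benzyl(ethyl)amino gives a 1.5-fold higher number from compound 2 to compound 3 (0.18 log units; within the scatter) in this assay. For the compounds shown here, this is the first step in which only one place differs, so a single change can now be read on its own. At this place, on a saturated chain carbon bound to an amine nitrogen, methyl in place of hydrogen does not move the number beyond the usual scatter of repeated measurements, and nothing available explains this result.

This one small step leaves open whether a larger group on that chain, such as propyl or a longer chain, would also stay within the scatter. As far as these compounds go, it is also open whether replacing the benzyl group with a different amine substituent, such as a carboxylic acid-bearing chain, would bring a clearer change.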